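Two Fluorinated Phenyl Groups on the Same Five-Membered Ring

The compounds below may be only part of what the source reports. "The series", "measured", "known", "first", "only" and "open" are said of these compounds alone.

Measured so far:
compound 1 `COc1ccc(/C=N/NC(=O)c2cc(OC)c(OC)c(OC)c2)c(OC)c1`: -6.9%
compound 2 `COc1cc(C2=NN(C(C)=O)C(c3ccccc3C(F)(F)F)O2)cc(OC)c1OC`: 31.8%
compound 3 `COc1cc(C(=O)N/N=C/c2ccc(Cl)c([N+](=O)[O-])c2)cc(OC)c1OC`: -5.8%

In a functional assay on BGC-823 cells (Homo sapiens) for antiproliferative activity, read by MTT assay, tested at 1 uM (on this read-out higher numbers stand for a stronger effect at the one concentration tested and lower numbers for a weaker effect), compound 2 gives 31.8%, the highest of the three numbers. Compound 3 stands lower by a gap beyond the scatter, and compound 1 stands lower still, also beyond the scatter. Compound 4 `COc1cc(C2=NN(C(C)=O)C(c3ccc(F)c(F)c3)O2)cc(OC)c1OC` carries one change relative to compound 2: 3,4-difluorophenyl in place of 2-(trifluoromethyl)phenyl on a saturated ring carbon. Among the compounds with values here, no pair of measured compounds shows the effect of such a swap, so the size of the step in this assay has no measured precedent. A modest drop is expected, and the estimated step is a number 6.8 percentage points lower from compound 2 to compound 4 (within the scatter), within the scatter or only slightly beyond it. For compound 4 the expected value is 25%, between 5% and 45%.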

Compound 4, a percentage reported as inhibition, at one concentration (the size of the read-out at that concentration, not a potency): 18.3%
Beside the measured number, compound 4's estimate is 6.7 percentage points above it, and the stated range covers the measured number.
By their numbers in this assay, from the lowest: compounds 1 and 3 (each within the scatter of the next); then compound 4; then compound 2.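

Within the data shown here, changing this one group, 3,4-difluorophenyl in place of 2-(trifluoromethyl)phenyl on a saturated ring carbon, gives a number 13.5 percentage points lower from compound 2 to compound 4 (beyond the scatter) in this assay and is the first measured swap at this position. The result shows that the read-out responds to which fluorinated phenyl group sits here, even though the rest of the molecule stays the same. Nothing measured explains the direction of this step.

A single swap cannot separate the effect of the group's fluorine atoms from that of their placement on the phenyl ring. Plain phenyl, or a phenyl ring carrying an amine, would test how much the fluorine atoms matter here.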